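A diethylamino group enters at the end of the chain

A few compounds are considered here, and "the series" means these few. Any claim that something is new, unique, unknown or untested is made for them only; others in the source may bear on it.

For the measured compounds named here, in a physicochemical assay for solubility, measured as kinetic solubility, at pH 7.4 (on this read-out higher numbers stand for higher solubility and lower numbers for lower solubility), three compounds sharing one core have numbers so far: compound 1 `COc1cc(N2CCC(C(=O)N3CCOCC3)CC2)ccc1Nc1nc(NC2CCCCC2)c2nc[nH]c2n1` gives 19000 nM, compound 2 `COc1cc(N2CCC(CC(=O)N3CCOCC3)CC2)ccc1Nc1nc(NC2CCCCC2)c2nc[nH]c2n1` gives 19000 nM and compound 3 `COc1cc(N2CCC(CC(=O)N3CCN(C)CC3)CC2)ccc1Nc1nc(NC2CCCCC2)c2nc[nH]c2n1` gives 38000 nM. Compound 3 thus stands within the usual scatter of both others. The next structure is compound 4 `CCN(CC)CC1CCN(c2ccc(Nc3nc(NC4CCCCC4)c4nc[nH]c4n3)c(OC)c2)CC1`, and the change is this: diethylamino in place of (4-methylpiperazin-1-yl)carbonyl on a saturated chain carbon bound to a saturated ring carbon. A six-membered non-aromatic ring leaves, and no ring enters.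

Going by the values given here, three measured steps bear on this change: no change at the digits printed from compound 1 to compound 2 (within the scatter), a 2.0-fold higher number from compound 1 to compound 3 (0.30 log units; within the scatter) and a 2.0-fold higher number from compound 2 to compound 3 (0.30 log units; within the scatter). Among the compounds with values here, all three stay within the scatter, but none of them removes the carbonyl, so the data offer no direct precedent and no direction can be argued. Read against those small steps, the expected change in this assay is none beyond the scatter, with the estimate being no change at the digits printed from compound 3 to compound 4 (within the scatter). Compound 4 is estimated at 38000 nM, with an expected range of 15000 nM to 95000 nM.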

Compound 4, solubility: 19000 nM
Estimate against measurement, compound 4: 2.0-fold (0.30 log units) above, within the range that was stated.
By their numbers in this assay, from the lowest: compounds 1, 2, 4 and 3 (each within the scatter of the next).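

For the compounds shown here, the diethylamino group is the first end group here that carries neither a carbonyl nor a ring, and in this assay the swap stays within the scatter against each earlier compound (a 2.0-fold lower number from compound 3 to compound 4 (0.30 log units; within the scatter); no change at the digits printed from compound 2 to compound 4 (within the scatter); no change at the digits printed from compound 1 to compound 4 (within the scatter)). On a saturated chain carbon bound to a saturated ring carbon, then, the carbonyl and the six-membered non-aromatic ring can both go, leaving fewer heavy atoms, with no step beyond the scatter in this read-out. Nothing shown gives a measured property of these groups that bears on this result.

Still open, going by these compounds, is whether a carboxylic acid or a piperidin-1-yl group at the same place would read the same. Also open, on these data alone, is whether a longer chain carrying the diethylamino group would produce a step beyond the scatter.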